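The source may report more compounds than this note shows. Statements on the series, on what has been measured and on what is new or still open speak of the compounds shown alone.

The measured compounds:

Compound 1, `c1ccc(-c2ccc(Cn3cncc3CNc3ccc(-c4ccc[nH]4)c(-c4ccccc4)c3)cc2)cc1`. In a toxicity assay on NIH3T3 cells (Mus musculus) for cytotoxicity, read by resazurin assay (on this read-out lower numbers stand for an effect already at smaller amounts and higher numbers for an effect only at larger amounts of compound), compound 1 gives only a limit of the assay, > 10000 nM.

Compound 2, `COC(=O)c1ccc(NCc2cncn2Cc2cccc(F)c2)cc1-c1ccccc1`. In this assay compound 2 gives only a limit, > 1000 nM.

Compound 3, `c1ccc(-c2ccc(Cn3cncc3CNc3ccc(-c4ccccc4)c(-c4ccccc4)c3)cc2)cc1`. In this assay compound 3 gives only a limit, > 10000 nM.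

Compound 2 therefore stands nowhere fixed on the numbers shown: its value is a limit, and the two other values are limits as well. One value sits at the limit of > 1000 nM in this assay, at which 1 of the 3 values shown sits, and two sit at the limit of > 10000 nM in this assay, at which 2 of the 3 values shown sit. Among the measured compounds shown here, the one step that differs in a single place, a step that the two limits leave unreadable from compound 1 to compound 3, cannot be read, since both of its ends are limits. For the measured compounds named here, no measured step bears on the change from compound 2 to compound 4, `COC(=O)c1ccc(NCc2cncn2Cc2ccc([N+](=O)[O-])cc2)cc1-c1ccccc1`, which is 4-nitrophenyl in place of 3-fluorophenyl on a saturated chain carbon bound to an aromatic nitrogen. With no readable step to lean on, and compound 2 itself at a limit, the expectation for compound 4 is that this assay again reports a limit rather than a number, the estimated step that the limit leaves unreadable from compound 2 to compound 4 being no more than a guess. Compound 4 is expected at about 10000 nM, in a range from 2000 nM to 50000 nM.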

Compound 4, half-maximal effective concentration: > 10000 nM
Compound 4: no number, only a limit; the forecaster's own chance of this, stated with the estimate: 85%; the middle value sits exactly at the limit.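

Compound 2 and compound 4 each give only a limit in this assay, so the change from 3-fluorobenzyl to 4-nitrobenzyl yields no readable step. The compounds shown leave open at what concentration any of them reaches its half-maximal effect in this assay.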